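Acetyl for methyl on the aryl oxygen of compound 1

The source may report more compounds than this note shows. Statements on the series, on what has been measured and on what is new or still open speak of the compounds shown alone.

Measured compounds:
compound 1, `COc1c(F)c(F)c(F)c(F)c1C(=O)O`, 53.8%
compound 2, `O=C(O)c1ccc(F)c(F)c1O`, no result reported
compound 3, `O=C(O)c1cc(F)c(F)cc1O`, no result reported

Among the compounds with values here, compound 1 is the only member of the series with a number. In a functional assay on the whole organism for inhibition, with Rattus norvegicus as the target, read by paw edema, with stated times of 30 min and 3 h, at a dose of 25 mg/kg by the intraperitoneal route (a higher number here means more inhibition at the dose given (going by the name of the read-out), a lower number less inhibition), compound 1 gives 53.8%. Within the data shown here, compound 2 and compound 3 carry no result in this assay, so compound 1 stands alone and no step between measured compounds can be read off. Nothing in the series says how large a change in the read-out is to be expected from any structural change.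

Compound 4, `CC(=O)Oc1c(F)c(F)c(F)c(F)c1C(=O)O`, differs from compound 1 in one place: acetyl in place of methyl on an oxygen on an aromatic ring. Among the measured compounds shown here, no pair with this difference has been measured, so the size of the step is unknown; with only the single value of compound 1 as anchor, no step beyond the usual scatter is expected in either direction. The step from compound 1 to compound 4 is therefore estimated as a number 3.8 percentage points lower from compound 1 to compound 4 (within the scatter). For compound 4 the estimated value in this assay is 50%, within a range from 30% to 70%.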

Compound 4, a percentage reported as inhibition, in the whole organism at one dose (the size of the read-out at that dose, not a potency): 42.9%
For compound 4 the middle estimate is 7.1 percentage points above the measured one; the range from low to high includes it.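

Within the data shown here, the first measured step shows that this position responds to change: in this assay, acetyl in place of methyl on an oxygen on an aromatic ring gives a number 10.9 percentage points lower from compound 1 to compound 4 (beyond the scatter). The step is modest, and it points towards less inhibition at the dose given for the acetoxy compound than for the methoxy compound. No measurement shown bears on the reason for this step.

A single pair gives the size of one change only, so it sets no trend for this position. On these data alone, whether a longer acyl chain such as propanoyl on this oxygen, or an amine in place of the oxygen, would keep or lower the inhibition remains open.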